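Fluoro Substitution Measured on Two Related Cores

The source may hold more compounds than are shown below. What is called first, only, known or untested is meant among the compounds shown, and "the series" means these compounds.

Compound 1, `COc1ccc(/C=C2\Cc3c(cc(OC)c(OC)c3OC)C2=O)cc1`: 273 nM
Compound 2, `COc1ccc(/C=C2\Cc3c(cc(OC)c(OC)c3OC)C2=O)cc1F`: 298 nM
Compound 3, `COc1ccc(/C=C2\CCc3c(cc(OC)c(OC)c3OC)C2=O)cc1`: 18900 nM

Of the compounds shown here, three have been measured in a functional assay on A549 cells (Homo sapiens) for antiproliferative activity, read by MTT assay, with a stated time of 48 h; a higher number here means a weaker inhibitor of growth, a lower number a stronger inhibitor of growth. Compound 1 gives 273 nM, compound 2 gives 298 nM and compound 3 gives 18900 nM. Compound 3 stands highest of the three, with a gap to compound 2 and to compound 1 that is beyond the usual scatter in this assay. How the core of compound 3 differs from the core of compound 1 is not broken down here.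

Compound 2 arises from compound 1 by one change, (fluoro in place of hydrogen on an aromatic carbon), and this step gave a 1.1-fold higher number from compound 1 to compound 2 (0.04 log units; within the scatter). The same change, (fluoro in place of hydrogen on an aromatic carbon), carries compound 3 to the unmeasured compound 4, `COc1ccc(/C=C2\CCc3c(cc(OC)c(OC)c3OC)C2=O)cc1F`; both times it sits on an aromatic carbon of a six-membered aromatic ring of carbon only, ortho to a methoxy group and meta to a large group, so the two places read the same.

Since the earlier step lay within the scatter, compound 4 is expected to sit close to compound 3, with an estimated step of a 1.1-fold higher number from compound 3 to compound 4 (0.02 log units; within the scatter) in this assay. That expectation rests on a single earlier pair, compound 1 and compound 2, measured on the other core, and may not carry over. Compound 4 is thus estimated at 20000 nM, between 8000 nM and 50000 nM.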

Compound 4, concentration for 50% growth inhibition: 15400 nM
Estimate against measurement, compound 4: 1.3-fold (0.11 log units) above; measured number inside the range.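

In this assay, the change from 4-methoxyphenyl to 3-fluoro-4-methoxyphenyl on the second core gave a 1.2-fold lower number from compound 3 to compound 4 (0.09 log units; within the scatter), so fluoro in place of hydrogen at this place left the number within the scatter here as well. Set beside the earlier step on the core of compound 1, the change reads the same on both cores, with no difference between the two steps that can be told from the scatter: the same change on two cores in this assay, a 1.1-fold higher number (0.04 log units; within the scatter) from compound 1 to compound 2 and a 1.2-fold lower number (0.09 log units; within the scatter) from compound 3 to compound 4, 1.3-fold (0.13 log units) apart, within the scatter of two such steps This shows only that a change with no readable effect on one core also had no readable effect on the other; it rests on just two pairs, a single position and a single cell line, and it does not show that a change with a step beyond the scatter would carry over between these cores in the same way.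

The compounds shown leave open whether a different group at this place, such as chloro, hydroxy, an amine or a longer alkoxy chain, would give a step beyond the scatter on either core. They also leave open how fluoro would read on other carbons of this ring, or on the ring bearing the three methoxy groups.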